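The source may hold more compounds than are shown below. What is called first, only, known or untested is meant among the compounds shown, and "the series" means these compounds.

Of the compounds shown here, three of a shared core have been measured so far. Compound 1 `Cc1cccc(-c2nc(CNc3ccc(C(=O)NO)cc3)n(-c3ccccc3)n2)c1` carries a 3-methylphenyl group on an aromatic carbon of a five-membered aromatic ring with 3 nitrogen, between two ring nitrogen atoms. In an assay on Sf9 cells for inhibition of protein deacetylase HDAC6 (Homo sapiens), read by fluorescence, with a stated time of 40 min, tested at 100 nM (on this read-out lower numbers stand for less inhibition and higher numbers for more inhibition at the one concentration tested (going by the name of the read-out)), compound 1 gives 64.1%. Compound 3 `O=C(NO)c1ccc(NCc2nc(-c3ccccc3)nn2-c2ccc(Br)cc2)cc1` gives 65.9%, a number within the scatter of that of compound 1, so the two cannot be told apart. Compound 2 `CC(C)c1ccc(-n2nc(-c3ccccc3)nc2CNc2ccc(C(=O)NO)cc2)cc1` gives 52.6%, and the reading of compound 1 lies beyond the scatter above it. Compound 1 therefore sits alongside compound 3 and clearly above compound 2 on the numbers shown.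

Among the measured compounds shown here, the one step between measured compounds that differ in a single place is a number 13.3 percentage points higher from compound 2 to compound 3 (beyond the scatter), and it concerns a different place in the molecule from the one changed here.

Compound 4 `Cc1ccsc1-c1nc(CNc2ccc(C(=O)NO)cc2)n(-c2ccccc2)n1` differs from compound 1 at the aromatic carbon between two ring nitrogen atoms: 3-methylthiophen-2-yl in place of 3-methylphenyl on an aromatic carbon. For the measured compounds named here, no measured step touches this place, and no measured compound carries a five-membered aromatic ring with 1 hetero atom there, so nothing in the data points in either direction. The expectation for compound 4 is therefore a step of a number 2.1 percentage points lower from compound 1 to compound 4 (within the scatter), that is, nothing beyond the scatter. Compound 4 is estimated at 62%, with a range from 48% to 76%.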

Compound 4, a percentage reported as inhibition, at one concentration (the size of the read-out at that concentration, not a potency): 72.1%
The estimate for compound 4 lay 10.1 percentage points below the measured number, and the stated range covers the measured number.
By their numbers in this assay, from the lowest: compound 2; then compounds 1, 3 and 4 (each within the scatter of the next).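

In this assay, among the compounds shown here, this is the first change at the aromatic carbon between two ring nitrogen atoms that can be read directly, and it gives a number 8 percentage points higher from compound 1 to compound 4 (within the scatter). The step therefore shows that a five-membered aromatic ring with 1 hetero atom, here sulfur, can stand at this place in place of a six-membered aromatic ring of carbon only with no change that can be told from the scatter, and it gives no ground for placing the number of either compound above the other. Nothing in the available data offers an explanation for how the reading responds to this exchange.

The compounds shown leave open whether the number stays level with groups of another kind at this place, such as a pyridine ring, a morpholine, a carboxylic acid or a longer alkyl chain, and whether the methyl group carried by both the 3-methylphenyl and the 3-methylthiophen-2-yl groups matters at all. They also leave open whether 3-methylthiophen-2-yl would behave the same way on a core bearing the bromo or isopropyl group of compound 3 or compound 2, and a reading at one concentration gives no potency for any of these compounds.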